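Ethyl on the nitrogen of compound 2

The source may hold more compounds than are shown below. What is called first, only, known or untested is meant among the compounds shown, and "the series" means these compounds.

In a functional assay on Chorioallantoic membrane (Gallus gallus, strain Leghorn), read by microscopy, with a stated time of 40 h (on this read-out higher numbers stand for weaker inhibition and lower numbers for stronger inhibition), two compounds with a shared core have been measured. Compound 1 `COc1ccc(N(C)c2ncnc3occ(C)c23)cc1` gives 80 nM and compound 2 `COc1ccc(Nc2ncnc3occ(C)c23)cc1` gives 445 nM as the higher of the two numbers, so compound 2 is the weaker inhibitor of the pair. Compound 3 `CCN(c1ccc(OC)cc1)c1ncnc2occ(C)c12` carries ethyl in place of hydrogen on a nitrogen on an aromatic ring, a change counted as ethyl in place of hydrogen on a nitrogen on an aromatic ring against compound 2. For the measured compounds named here, one measured step bears on this: a 5.6-fold higher number from compound 1 to compound 2 (0.75 log units; beyond the scatter) when hydrogen takes the place of methyl on that nitrogen. Read in reverse, it points to a lower number for compound 3, although no ethyl on this nitrogen has been measured. In this assay a change of similar or somewhat smaller size is therefore expected, with a 3.0-fold lower number from compound 2 to compound 3 (0.47 log units; beyond the scatter) as the estimated step. For compound 3 the expected value is 150 nM (estimated range 50 nM to 450 nM).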

Compound 3, half-maximal inhibitory concentration: 812 nM
Compound 3: middle estimate off by 5.4-fold (0.73 log units), on the low side; the measured number lies above the stated range.
By their numbers in this assay, from the lowest: compound 1; then compounds 2 and 3 (each within the scatter of the next).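

Ethyl on this nitrogen does not set compound 3 apart from compound 2 in this assay, with a 1.8-fold higher number from compound 2 to compound 3 (0.26 log units; within the scatter). Going from methyl to ethyl on the same nitrogen instead gives a 10-fold higher number from compound 1 to compound 3 (1.01 log units; beyond the scatter), so among these three compounds only the methyl of compound 1 stands apart, and compound 3 shows that filling this position with an alkyl group does not by itself carry the lower number of compound 1. Nothing available here explains why methyl and ethyl part so sharply at this nitrogen.

The compounds shown leave open whether propyl or a longer chain on this nitrogen would stay with compound 2 and compound 3. They also leave open whether a small ring such as cyclopropyl would read like methyl or like ethyl.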